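Solubility of a pyrazole amide: a projection from compound 2

A few compounds are considered here, and "the series" means these few. Any claim that something is new, unique, unknown or untested is made for them only; others in the source may bear on it.

Of the compounds shown here, three have been measured in a physicochemical assay for solubility, read by HPLC, in phosphate buffer, measured as kinetic solubility, at pH 7.4; on this read-out higher numbers stand for higher solubility and lower numbers for lower solubility. Compound 1 `CCC(=O)c1cc(-c2cccc(Cl)c2)n(-c2ccc(S(N)(=O)=O)cc2)c1C` gives 12600 nM in this assay, compound 3 `CCC(=O)c1cc(-c2ccc(S(N)(=O)=O)cc2)n(-c2ccc(Cl)cn2)n1` gives 33700 nM, and compound 2 `CC(C)(C)C(=O)c1cc(-c2ccc(S(N)(=O)=O)cc2)n(-c2ccc(Cl)cc2)n1` gives 6600 nM. Compound 2 thus stands lowest among the measured numbers; its gap to compound 1 lies within the scatter of the assay, so no order between those two can be read, whereas the gap to compound 3 lies beyond the scatter. Among the compounds with values here, no two of the measured compounds differ in only one place, so no single structural step can be traced among them.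

Compound 4 `NS(=O)(=O)c1ccc(-c2cc(C(=O)NC3CC3)nn2-c2ccc(Cl)cc2)cc1` has not yet been measured. Compared with compound 2 it shows one change: cyclopropylamino in place of tert-butyl on a carbonyl carbon. Within the data shown here, since no comparable step is available among the measured compounds, the size of the step to compound 4 is open. The account expects a moderate rise in this assay, with a step of a 2.3-fold higher number from compound 2 to compound 4 (0.36 log units; beyond the scatter) that may or may not clear the scatter. Compound 4 is accordingly estimated at 15000 nM in this assay, with a range from 6000 nM to 40000 nM.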

Compound 4, solubility: 72600 nM
Compound 4: the middle estimate sits 4.8-fold (0.68 log units) below what was measured; measured number above the stated range.
By their numbers in this assay, from the lowest: compounds 2 and 1 (each within the scatter of the next); then compound 3; then compound 4.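

In this assay the substituent on the carbonyl carbon turns out to matter a great deal: cyclopropylamino in place of tert-butyl brings an 11-fold higher number from compound 2 to compound 4 (1.04 log units; beyond the scatter) and gives the series its first step that can be traced to a single place. Both groups hold 4 heavy atoms, so the step comes without any change in that count, while the entering group brings a nitrogen, a three-membered ring of carbon and a hydrogen-bond donor that the leaving group lacks. Nothing at hand bears on why the number moves this far, so the step stands as an observation without an explanation.

The compounds shown leave open which part of the new group goes with the rise, the amide hydrogen, the nitrogen or the three-membered ring; isopropylamino or dimethylamino on the same carbonyl carbon would begin to separate these. From the compounds shown here alone, it also remains open whether the same change would give a step of similar size on the core of compound 3, or whether it holds only on the core of compound 2.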